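A fluorophenyl isomer pair in the series

The source may report more compounds than this note shows. Statements on the series, on what has been measured and on what is new or still open speak of the compounds shown alone.

Of the compounds shown here, two have been measured so far in a physicochemical assay for lipophilicity; on this read-out higher numbers stand for higher lipophilicity and lower numbers for lower lipophilicity. Compound 1 `Nc1ccccc1NC(=O)c1ccc(CNC2=N[C@@H](Cc3ccccc3)CO2)cc1` gives 4.15, and compound 2 `Nc1ccccc1NC(=O)c1ccc(CNC2=NC(c3ccc(F)cc3)CO2)cc1` gives 3.97. These two values lie within the usual scatter of each other, so compound 2 stands level with compound 1 on the numbers available. Compound 3 `Nc1ccccc1NC(=O)c1ccc(CNC2=NC(c3cccc(F)c3)CO2)cc1` has not yet been measured. It carries 3-fluorophenyl in place of 4-fluorophenyl on a saturated ring carbon, next to the ring nitrogen (3-fluorophenyl in place of 4-fluorophenyl on a saturated ring carbon). Going by the values given here, no measured pair shows a change of this kind, so the expectation rests only on compound 2 at 3.97 and on the two structures having the same atoms, joined differently. The expected a number 0.03 log units higher from compound 2 to compound 3 (within the scatter) is estimated to stay within the scatter, with no direction favoured. Compound 3 is estimated at 4, with an expected range from 3.7 to 4.3.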

Compound 3, partition coefficient: 3.84
Compound 3: the middle estimate sits 0.16 log units above what was measured; the range from low to high includes it.
By their numbers in this assay, from the lowest: compounds 3, 2 and 1 (each within the scatter of the next, the first and the last beyond it).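

In this assay, 3-fluorophenyl in place of 4-fluorophenyl on a saturated ring carbon, next to the ring nitrogen, gives a number 0.13 log units lower from compound 2 to compound 3 (within the scatter). Going by these compounds alone, this is the first measured pair for this position, and it gives no reading of a difference between the two fluorophenyl isomers on this read-out. Within this pair, the step leaves the two compounds level, although the claim extends only to compound 2 and compound 3, and nothing at hand bears on why the step has this size.

On these data alone, what a group other than a fluorophenyl would give on the same ring carbon remains open, for instance a methoxyphenyl, a pyridyl or a carboxylic acid. As far as these compounds go, whether the two isomers also stay level on any other read-out remains open too.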